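2-Cyanoethoxy in place of naphthalen-1-yl: working notes

The source may hold more compounds than are shown below. What is called first, only, known or untested is meant among the compounds shown, and "the series" means these compounds.

Of the compounds shown here, two have been measured so far in a functional assay on CCRF-CEM cells (Homo sapiens) for inhibition; a lower number here means a stronger inhibitor, a higher number a weaker inhibitor. Compound 1 `Cc1cccc(-c2cnc(Nc3ccc4c(C#N)cn(C)c4c3)o2)c1` gives only a limit, > 10000 nM. Among the measured compounds shown here, compound 2 `Cn1cc(C#N)c2ccc(Nc3ncc(-c4cccc(CNC(=O)c5cccc6ccccc56)c4)o3)cc21` gives 2500 nM, the only actual number, so it has no numerical comparator yet.

The next compound to be tested is compound 3 `Cn1cc(C#N)c2ccc(Nc3ncc(-c4cccc(CNC(=O)OCCC#N)c4)o3)cc21`, in which 2-cyanoethoxy stands in place of naphthalen-1-yl on a carbonyl carbon (2-cyanoethoxy in place of naphthalen-1-yl on a carbonyl carbon). For the measured compounds named here, no measured step shows what this kind of change does, so the expectation is loose. A modest expected step of a 2.0-fold higher number from compound 2 to compound 3 (0.30 log units; within the scatter) towards weaker inhibition is the working guess, and a result within the scatter would not be surprising. A fall to the limit of this assay also remains possible. For compound 3 the estimated value is 5000 nM, with an expected range of 2000 nM to 10000 nM.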

Compound 3, half-maximal inhibitory concentration: > 10000 nM
Compound 3: a limit, no number (the forecaster's own chance of this, stated with the estimate: 35%); middle value at least 2.0-fold (0.30 log units) away from the limit.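

In this assay, among the compounds shown here, 2-cyanoethoxy in place of naphthalen-1-yl on a carbonyl carbon gives an at least 4.0-fold higher number from compound 2 to compound 3 (0.60 log units; beyond the scatter), the first readable step. This position, on a carbonyl carbon whose other neighbour is an amide-type nitrogen, therefore does not tolerate every group: the change removes two six-membered aromatic rings of carbon only and is accompanied by weaker inhibition. The reading for compound 3 is a limit and not a number, so the true size of the step stays unknown: the limit of > 10000 nM in this assay, at which 2 of the 3 values shown sit.

The step between compound 1 and compound 3 cannot be read, as both values are limits. Also open, on these data alone, is whether the aromatic rings, the oxygen or the nitrile matters here; a phenyl, a benzyloxy or a simple ethoxy group on the same carbonyl carbon would help separate these.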